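A few compounds are considered here, and "the series" means these few. Any claim that something is new, unique, unknown or untested is made for them only; others in the source may bear on it.

In a functional assay on DU-145 cells (Homo sapiens) for cytotoxicity, read by MTT assay (a higher number here means a weaker inhibitor, a lower number a stronger inhibitor), compound 3 `CC(=O)OCCO[C@H](CC=C(C)C)C1=CC(=O)c2c(O)ccc(O)c2C1=O` gives 15500 nM. Compound 2 `CC(C)=CC[C@@H](OC[C@@H](C)O)C1=CC(=O)c2c(O)ccc(O)c2C1=O` gives 14300 nM, and the gap, a 1.1-fold higher number from compound 2 to compound 3 (0.03 log units; within the scatter), leaves the two level. Compound 1 `CCCC(O)CC(=O)O[C@H](CC=C(C)C)C1=CC(=O)c2c(O)ccc(O)c2C1=O` reaches only a limit of the assay, > 100000 nM.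

Compound 4 `CC[C@](C)(O)CC(=O)O[C@H](CC=C(C)C)C1=CC(=O)c2c(O)ccc(O)c2C1=O` has not yet been measured. It differs from compound 3 as follows: (2-hydroxy-2-methylbutyl)carbonyl in place of 2-acetoxyethyl on an oxygen on a saturated carbon. The entering (2-hydroxy-2-methylbutyl)carbonyl sits on an oxygen on a saturated carbon, where compound 1 has (2-hydroxypentyl)carbonyl, so compound 1 is the closest guide.

Among the compounds with values here, two measured steps bear on this change. Leaving that group of compound 1 for 2-acetoxyethyl gave an at least 6.4-fold lower number from compound 1 to compound 3 (0.80 log units; beyond the scatter), and leaving it for 2-hydroxypropyl gave an at least 6.9-fold lower number from compound 1 to compound 2 (0.84 log units; beyond the scatter). On these data alone, both start from a limit, so their full size is unknown. Replacing 2-acetoxyethyl with a similar carbonyl group should therefore run the other way, towards a higher number and a weaker inhibitor in this assay. The expected change is a 3.9-fold higher number from compound 3 to compound 4 (0.59 log units; beyond the scatter). The estimated value for compound 4 is 60000 nM, within an expected range of 15000 nM to 200000 nM.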

Compound 4, half-maximal inhibitory concentration: 20500 nM
Compound 4: middle estimate off by 2.9-fold (0.47 log units), on the high side; the range from low to high includes it.
By their numbers in this assay, from the lowest: compounds 2, 3 and 4 (each within the scatter of the next). At a limit, above all of these: compound 1.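

In this assay, compound 1 alone carried a carbonyl group on this oxygen, so that group might have seemed enough to lose the activity. Compound 4 carries one too, yet it sits level with the compounds lacking it, with a 1.3-fold higher number from compound 3 to compound 4 (0.12 log units; within the scatter) and a 1.4-fold higher number from compound 2 to compound 4 (0.16 log units; within the scatter). What separates compound 1 from compound 4 is a single change on a saturated chain carbon bound to a carbonyl carbon, 1-hydroxy-1-methylpropyl in place of 1-hydroxybutyl, which gives an at least 4.8-fold lower number from compound 1 to compound 4 (0.68 log units; beyond the scatter), and the full size of this step stays unknown since it starts from a limit: the limit of > 100000 nM in this assay, at which 1 of the 4 values shown sits.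

The compounds shown do not tell whether the branching of this chain is enough or whether its hydroxyl is also needed. A plain 1-methylpropyl group, or an amine in place of that hydroxyl, would separate the two.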